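The source may hold more compounds than are shown below. What is called first, only, known or untested is meant among the compounds shown, and "the series" means these compounds.

Of the compounds shown here, two have numbers so far in a functional assay (muscle tissue) with Rattus norvegicus as the target; on this read-out lower numbers stand for an effect already at smaller amounts and higher numbers for an effect only at larger amounts of compound. Compound 1 `CNC(=O)C1=CC(C)(C)Oc2ccc(C#N)cc21` gives 263 nM. Compound 2 `CCCNC(=O)C1=CC(C)(C)Oc2ccc([N+](=O)[O-])cc21` gives 5.75 nM, the lower of the two numbers, and its gap to compound 1 lies beyond the scatter. Among the measured compounds shown here, the series offers no measured pair that differs in one place only, so no measured step is available as a guide. Compound 3 `CC1(C)C=C(C(=O)NCC2CC2)c2cc([N+](=O)[O-])ccc2O1` has not yet been measured in this assay. Relative to compound 2, it carries cyclopropyl in place of ethyl on a saturated chain carbon bound to an amide-type nitrogen; the same difference reads as propyl to cyclopropylmethyl. No step beyond the scatter is expected, in either direction. The estimated step is a 1.2-fold higher number from compound 2 to compound 3 (0.09 log units; within the scatter). The expected value for compound 3 is 7 nM, within an estimated range of 2.5 nM to 20 nM.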

Compound 3, half-maximal effective concentration: 6.61 nM
Compound 3: middle estimate off by 1.1-fold (0.02 log units), on the high side, and the stated range covers the measured number.
By their numbers in this assay, from the lowest: compounds 2 and 3 (each within the scatter of the next); then compound 1.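

Among the compounds shown here, at the saturated chain carbon bound to an amide-type nitrogen, cyclopropyl in place of ethyl gives a 1.1-fold higher number from compound 2 to compound 3 (0.06 log units; within the scatter) in this assay, the first step that can be read from a single change. This position therefore takes one three-membered non-aromatic ring of carbon only, and one more heavy atom, with no shift beyond the scatter between compound 2 and compound 3. Nothing measured here offers an explanation for this result.

On these data alone, compound 1 differs from compound 2 and compound 3 in more than one place, so the steps to it cannot be read, and the separate contributions of its methyl on the amide nitrogen and its nitrile remain open. Also open, as far as these compounds go, is how this read-out responds at the same position to a longer chain, a phenyl ring or a terminal amine.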